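Adding tert-butoxycarbonyl to the amine of compound 2

The source may hold more compounds than are shown below. What is called first, only, known or untested is meant among the compounds shown, and "the series" means these compounds.

In a functional assay on IGROV-1 cells (Homo sapiens) for inhibition, with a stated time of 72 h (a lower number here means a stronger inhibitor, a higher number a weaker inhibitor), compound 2 (`O=C(/C=C/c1ccc(CNCc2ccccc2)cc1)NO`) gives 480 nM, level within the scatter with compound 1 (`CC(C)(C)OC(=O)N(Cc1ccccc1)Cc1ccc(/C=C/C(=O)NOC2CCCCO2)cc1`) at 530 nM. Compound 3 (`CC(C)(C)OC(=O)N(Cc1ccccc1)Cc1ccc(/C=C/C(=O)NO)cc1`) is compound 2 with one change: tert-butoxycarbonyl in place of hydrogen on an amine nitrogen. Going by the values given here, compound 1 carries tert-butoxycarbonyl on the same amine nitrogen, but it also differs from compound 3 elsewhere, so no measured pair isolates this change. A modest step toward stronger inhibition in this assay is expected, about the size of the scatter: a 1.8-fold lower number from compound 2 to compound 3 (0.27 log units; within the scatter). The estimate for compound 3 is 260 nM, with an expected range of 80 nM to 800 nM.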

Compound 3, half-maximal inhibitory concentration: 19100 nM
Estimate against measurement, compound 3: 73-fold (1.87 log units) below; measured number outside the range, above it.
By their numbers in this assay, from the lowest: compounds 2 and 1 (each within the scatter of the next); then compound 3.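

On the amine nitrogen, tert-butoxycarbonyl in place of hydrogen gives a 40-fold higher number from compound 2 to compound 3 (1.60 log units; beyond the scatter) in this assay, so this position does not tolerate the change in the free hydroxamic acid series. The oxygen position also matters: hydrogen in place of oxan-2-yl gives a 36-fold higher number from compound 1 to compound 3 (1.56 log units; beyond the scatter) with tert-butoxycarbonyl kept on the amine. No measurement offers an explanation for either step. Still open, on these data alone, is whether a methyl or an acetyl on the same amine nitrogen brings a comparable rise. Also open, as far as these compounds go, is what oxan-2-yl on the oxygen does when the amine keeps its hydrogen.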